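Removing one methoxy group from a trimethoxyanilino quinone

A few compounds are considered here, and "the series" means these few. Any claim that something is new, unique, unknown or untested is made for them only; others in the source may bear on it.

Measured compounds:
compound 1 `COc1cc(NC2=CC(=O)c3ncncc3C2=O)cc(OC)c1OC` gives 1500 nM
compound 2 `CC(=O)c1cccc(NC2=CC(=O)c3ncncc3C2=O)c1` gives 2300 nM
compound 3 `O=C1C(Nc2ccc(-c3ccc(F)cc3)cc2)=CC(=O)c2ncncc21` gives 3500 nM

Three anilino-substituted compounds sharing one core were tested in a functional assay on MIA PaCa-2 cells (Homo sapiens) for cytotoxicity, read by MTT assay, with a stated time of 72 h; a higher number here means a weaker inhibitor, a lower number a stronger inhibitor. Compound 1 gives the lowest of the three numbers. Compound 2 lies close to it, and the two values fall within the scatter of repeated measurements, so no order between them can be claimed. Compound 3 sits further away, and its gap to compound 1 lies beyond the scatter.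

The next compound, compound 4 `COc1cc(NC2=CC(=O)c3ncncc3C2=O)cc(OC)c1`, has not yet been measured. It differs from compound 1 in one place: hydrogen in place of methoxy on an aromatic carbon. The two remaining methoxy groups stay in place.

Among the measured compounds shown here, no step between measured compounds exists that would show what removing a methoxy group does on this core, so the expectation rests on the number for compound 1 alone. For the measured compounds named here, with no such precedent, the step is expected to be small: compound 4 is estimated to give a number close to that of compound 1, and the step of a 1.3-fold higher number from compound 1 to compound 4 (0.12 log units; within the scatter) is expected to stay within or only slightly beyond the scatter, if anything toward a weaker inhibitor. Compound 4 is therefore expected to give about 2000 nM, in a range from 900 nM to 4500 nM.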

Compound 4, half-maximal inhibitory concentration: 7700 nM
Beside the measured number, compound 4's estimate is 3.9-fold (0.59 log units) below it, outside the stated range (above it).
By their numbers in this assay, from the lowest: compounds 1, 2 and 3 (each within the scatter of the next, the first and the last beyond it); then compound 4.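

In this assay, the shared core now has its first step in one place, a 5.1-fold higher number from compound 1 to compound 4 (0.71 log units; beyond the scatter), which is beyond the scatter and toward a weaker inhibitor. It shows that this position is not indifferent to the change: with hydrogen entering in place of the methoxy group that sits ortho to two methoxy groups and para to a large group, the two methoxy groups that stay do not hold compound 4 at the level of compound 1, at 1500 nM. Nothing among the data given accounts for the size or the direction of this step.

Whether a hydroxyl group, a methyl group, a fluorine atom or an ethoxy group on this carbon would bring the number back toward that of compound 1 stays open; the one-place comparison shown holds only methoxy and hydrogen there. From the compounds shown here alone, it also remains open whether either of the other two methoxy groups matters to the same degree, and whether this step would keep its size on another core or in another cell line.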